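Replacing the aryl ether group of compound 2

This account rests on a few compounds, and the source may have more. Where it says the series, first, only, none or still open, it means among the compounds named here.

Readings in a functional assay for inhibition, with Homo sapiens as the target; on this read-out higher numbers stand for weaker binding and lower numbers for tighter binding:
- compound 1 `O=C(O)CC/C=C\CC1COC(c2ccc([N+](=O)[O-])cc2)OC1c1cccnc1`: 933 nM
- compound 2 `CSc1ccc(OC(C)(C)C2OCC(C/C=C\CCC(=O)O)C(c3cccnc3)O2)c([N+](=O)[O-])c1`: 4.47 nM

Of the two measured compounds, compound 2 has the lower number at 4.47 nM, and its gap to compound 1 lies beyond the scatter. Compound 3 `CC(C)(Oc1ccccc1F)C1OCC(C/C=C\CCC(=O)O)C(c2cccnc2)O1` has not yet been measured. It differs from compound 2 in one place: a group of 7 heavy atoms (6 carbon, 1 fluorine; one six-membered aromatic ring of carbon only) in place of a group of 11 heavy atoms (7 carbon, 1 nitrogen, 2 oxygen, 1 sulfur; one six-membered aromatic ring of carbon only), on an oxygen on a saturated carbon. The incoming 2-fluorophenyl sits on an oxygen on a saturated carbon, and the rest of compound 2 is unchanged.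

Going by the values given here, the two measured compounds differ in more than one place, so no single-place step is available as a guide, and nothing measured tests this exchange directly. Among the compounds with values here, the only close reference is compound 2 at 4.47 nM, the lower of just two values. A move to a higher number, meaning weaker binding in this assay, is therefore expected, probably beyond the scatter, though with wide uncertainty. The estimated change is an 8.9-fold higher number from compound 2 to compound 3 (0.95 log units; beyond the scatter). The expected value for compound 3 is 40 nM, with an estimated range of 8 nM to 200 nM.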

Compound 3, dissociation constant: 166 nM
The estimate for compound 3 lay 4.2-fold (0.62 log units) below the measured number; measured number inside the range.
By their numbers in this assay, from the lowest: compound 2; then compound 3; then compound 1.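

In this assay, the group on the oxygen on a saturated carbon proves to be a strong determinant of the read-out: with the rest of the molecule unchanged, the exchange for 2-fluorophenyl gives a 37-fold higher number from compound 2 to compound 3 (1.57 log units; beyond the scatter) and marks a large step beyond the scatter. The change replaces a group of 11 heavy atoms with 3 hydrogen-bond acceptors and 1 double bond outside aromatic rings by one of 7 heavy atoms with no hydrogen-bond acceptors, so several features shift together and this single step cannot assign the loss to any one of them. No measurement on hand bears on the reason for the step.

Still open, going by these compounds, is which part of the group in compound 2 accounts for the lower number, and whether a plain phenyl or a phenyl carrying only an amine would read close to compound 2 or to compound 3. Also open, on these data alone, is whether a chlorine or a methoxy group in place of the fluorine would move the number at all, and whether any smaller group can match compound 2.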